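The compounds below may be only part of what the source reports. "The series", "measured", "known", "first", "only" and "open" are said of these compounds alone.

The measured compounds so far:

Compound 1, `CCOc1ccccc1C[C@H]1COC(=O)[C@@H]1Cc1ccc(Cl)c(Cl)c1`: in a functional assay on HL-60 cells (Homo sapiens) for cytotoxicity, read by WST assay, with a stated time of 48 h (on this read-out lower numbers stand for an effect already at smaller amounts and higher numbers for an effect only at larger amounts of compound), compound 1 gives 15000 nM.
Compound 2, `CCCCOc1ccccc1C[C@H]1COC(=O)[C@@H]1Cc1ccc(Cl)c(Cl)c1`: in this assay compound 2 gives 10000 nM.
Compound 3, `CCc1ccc(C[C@H]2COC[C@@H]2Cc2ccc(Cl)c(Cl)c2)cc1`: in this assay compound 3 gives 26000 nM.

Compound 2 differs from compound 1 in a single place, (ethyl in place of hydrogen on a saturated chain carbon, two bonds along the chain from an oxygen on an aromatic ring). Measured, that change gave a step of a 1.5-fold lower number from compound 1 to compound 2 (0.18 log units; within the scatter), so the two numbers cannot be told apart with confidence.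

Compound 4, `CCCCc1ccc(C[C@H]2COC[C@@H]2Cc2ccc(Cl)c(Cl)c2)cc1`, has not been measured. It stands to compound 3 as compound 2 stands to compound 1: the difference is ethyl in place of hydrogen on a saturated chain carbon, two bonds along the chain from an aromatic carbon. The surroundings of the place are not identical, though. In compound 1 the chain sits two bonds along from an oxygen on an aromatic ring, in compound 3 two bonds along from an aromatic carbon, so this is the same kind of change rather than the same change. How the core of compound 3 differs from the core of compound 1 is not broken down here.

In this assay the step from compound 3 to compound 4 is expected to be about a 1.5-fold lower number from compound 3 to compound 4 (0.18 log units; within the scatter), because the earlier step of a 1.5-fold lower number from compound 1 to compound 2 (0.18 log units; within the scatter) was small. Compound 4 is therefore estimated at 17000 nM, with a plausible range from 7000 nM to 40000 nM.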

Compound 4, half-maximal effective concentration: 23000 nM
Compound 4: middle estimate off by 1.4-fold (0.13 log units), on the low side; measured number inside the range.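

In this assay, putting ethyl in place of hydrogen on the saturated chain carbon, which turns an ethyl chain into a butyl chain, gives a 1.1-fold lower number from compound 3 to compound 4 (0.05 log units; within the scatter). Set beside the earlier case, the change behaves alike on both cores, in the sense that neither step can be told apart from the scatter of repeated measurements: the same change on two cores in this assay, a 1.5-fold lower number (0.18 log units; within the scatter) from compound 1 to compound 2 and a 1.1-fold lower number (0.05 log units; within the scatter) from compound 3 to compound 4, 1.3-fold (0.12 log units) apart, within the scatter of two such steps This does not show that the two cores would always respond alike, since two small steps say nothing about how they would respond to a change that moves the number clearly, and two pairs are too few to support a general rule.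

Still open, going by these compounds, is whether a chain longer than butyl, or a chain ending in an amine or a carboxylic acid, would give a readable step on either core. On these data alone, all of these values come from this assay, and how the change behaves on any other read-out also remains open.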